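Piperidine attachment on the chain of the benzimidazole series

The source may report more compounds than this note shows. Statements on the series, on what has been measured and on what is new or still open speak of the compounds shown alone.

Compound 2 `Clc1ccc(OCc2nc3ccccc3n2CCCN2CCCCC2)cc1` gives 7020 nM in an assay on isolated protein for binding affinity to Neuropeptide Y receptor type 1 (Homo sapiens); on this read-out lower numbers stand for stronger inhibition and higher numbers for weaker inhibition. Among the three numbers it stands second highest: compound 1 `Clc1ccc(OCc2nc3ccccc3n2CCC2CCCCN2)cc1` with 7860 nM lies nearest, within the scatter, and compound 3 `Clc1ccc(OCc2nc3c(OCCCN4CCCCC4)cccc3n2CCCC2CCCNC2)cc1` with 1.7 nM lies furthest, beyond it. The step to compound 4 `Clc1ccc(OCc2nc3ccccc3n2CCCC2CCCNC2)cc1` is piperidin-3-yl in place of piperidin-1-yl on a saturated chain carbon, three bonds along the chain from an aromatic nitrogen.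

Among the measured compounds shown here, the only measured step in one place, a 1.1-fold lower number from compound 1 to compound 2 (0.05 log units; within the scatter), moved the chain-borne piperidine between two attachment points without any shift beyond the scatter. That does not settle the present change. Compound 4 shares its piperidin-3-yl chain with compound 3. In this assay compound 3 gives 1.7 nM, but it also bears a 3-(piperidin-1-yl)propoxy group on the core, so its number cannot be assigned to the chain alone. Compound 4 is therefore expected to fall between those anchors, with a downward step a 23-fold lower number from compound 2 to compound 4 (1.37 log units; beyond the scatter) expected from compound 2. The estimate for compound 4 is 300 nM, with a range from 30 nM to 3000 nM.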

Compound 4, inhibition constant: 700 nM
Compound 4: the middle estimate sits 2.3-fold (0.37 log units) below what was measured, and the stated range covers the measured number.
By their numbers in this assay, from the lowest: compound 3; then compound 4; then compounds 2 and 1 (each within the scatter of the next).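

In this assay, the attachment of the piperidine on the chain now registers: a 10-fold lower number from compound 2 to compound 4 (1.00 log units; beyond the scatter), and an 11-fold lower number from compound 1 to compound 4 (1.05 log units; beyond the scatter), whereas the earlier step between the other two attachments stayed within the scatter. With the piperidin-3-yl chain held constant, hydrogen in place of 3-(piperidin-1-yl)propoxy on an aromatic carbon gives a 410-fold higher number from compound 3 to compound 4 (2.61 log units; beyond the scatter), so the low number of compound 3 cannot come from the chain alone. No measurement at hand bears on the reason for either step.

On these data alone, whether the gain from piperidin-3-yl carries over when 3-(piperidin-1-yl)propoxy is on the core remains open. Also open, as far as these compounds go, is how the number responds to a 1-methylpiperidin-3-yl group, which lacks the ring's hydrogen-bond donor, or to a longer chain carrying the piperidin-3-yl ring.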